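Dihydropyridine series: aryl exchange at the saturated ring carbon

The source may hold more compounds than are shown below. What is called first, only, known or untested is meant among the compounds shown, and "the series" means these compounds.

Compound 1 `COC(=O)C1=C(C)N=C(C)/C(=C(\O)OC)C1c1ccc(I)cc1` gives 22900 nM in a functional assay (muscle tissue) with Cavia porcellus as the target; a higher number here means that more compound is needed for the effect, a lower number that less compound is needed. Within the data shown here, compound 2 `COC(=O)C1=C(C)N=C(C)/C(=C(\O)OC)C1c1ccccc1C#N` gives 15.9 nM in this assay, the lowest of the two numbers; its nearest neighbour is compound 1, and the single measured step is a 1400-fold lower number from compound 1 to compound 2 (3.16 log units; beyond the scatter). Compound 3 `COC(=O)C1=C(C)N=C(C)/C(=C(\O)OC)C1c1c(Cl)cccc1Cl` differs from compound 2 thus: 2,6-dichlorophenyl in place of 2-cyanophenyl on a saturated ring carbon. Among the measured compounds shown here, that large step set 4-iodophenyl against 2-cyanophenyl; no step exchanges one 2-substituted phenyl for another, so only a small step, if any beyond the scatter, is expected, a 1.6-fold lower number from compound 2 to compound 3 (0.20 log units; within the scatter). For compound 3 the estimated value is 10 nM, within a range of 2 nM to 60 nM.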

Compound 3, half-maximal effective concentration: 1.91 nM
Estimate against measurement, compound 3: 5.2-fold (0.72 log units) above, and the stated range ends above it.
By their numbers in this assay, from the lowest: compound 3; then compound 2; then compound 1.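

In this assay the aryl group on the saturated ring carbon still matters among groups other than 4-iodophenyl: 2,6-dichlorophenyl in place of 2-cyanophenyl gives an 8.3-fold lower number from compound 2 to compound 3 (0.92 log units; beyond the scatter) and so separates two aryl groups that the earlier step could not. Set against 4-iodophenyl, the same group gives a 12000-fold lower number from compound 1 to compound 3 (4.08 log units; beyond the scatter) and widens the span seen at this position. Nothing available explains either step.

Going by these compounds, it remains open whether a single chlorine, as in 2-chlorophenyl, gives the same number as 2,6-dichlorophenyl. On these data alone, the effect of a 2-iodophenyl group at this position also remains open.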